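Stereoisomers at the stability limit

This account rests on a few compounds, and the source may have more. Where it says the series, first, only, none or still open, it means among the compounds named here.

compound 1 `O=C(O)[C@@H](CO)NC(=O)[C@H]1C[C@H](O)CN1` gives > 12 h (a limit)
compound 2 `O=C(N[C@H](CO)C(=O)O)[C@@H]1C[C@H](O)CN1` gives > 12 h (a limit)
compound 3 `O=C(N[C@H](CO)C(=O)O)[C@@H]1C[C@@H](O)CN1` gives > 12 h (a limit)

Compound 3 stands at > 12 h in a physicochemical assay for metabolic stability, read by HPLC, with a stated time of 12 h, at pH 4.5 (a lower number here means that the compound disappears faster, a higher number that the compound lasts longer), as a limit and not a number. Compound 4 `O=C(O)[C@H](CO)NC(=O)[C@@H]1C[C@@H](O)CN1` alters only a stereocentre at a saturated chain carbon: the two compounds have the same atoms and bonds and differ only in configuration as drawn: 1 of 3 stereo elements differ; a stereocentre at a saturated chain carbon is drawn R in compound 3 and S in compound 4 is the whole change. The nearest measured steps are a step that the two limits leave unreadable from compound 1 to compound 2 and a step that the two limits leave unreadable from compound 2 to compound 3 and a step that the two limits leave unreadable from compound 1 to compound 3 and all three concern ring carbons. None has a readable size, and none alters the chain carbon. The estimated step is a step that the limit leaves unreadable from compound 3 to compound 4 and no change beyond the scatter is expected in either direction. Compound 4 is estimated at 24 h with an expected range from 12 h to 48 h as half-life.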

Compound 4, half-life: > 12 h
Compound 4 gave a limit, no number; the forecaster's own chance of this, stated with the estimate: 90%; the middle value is on the limit's open side.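

In this assay compound 4 gives > 12 h, a limit and not a number. Among these compounds, no step to it from compound 1, compound 2 or compound 3 can be read. The compounds shown leave open whether inverting any stereocentre, ring or chain, changes the half-life.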